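The source may report more compounds than this note shows. Statements on the series, on what has been measured and on what is new or still open speak of the compounds shown alone.

Measured so far:
compound 1, `CC1=CC[C@H](C(C)(C)NC(=S)NN)CC1`: > 100000 nM
compound 2, `CC1=CC[C@H](C(C)(C)NC(=S)N/N=C/c2ccco2)CC1`: 26900 nM

In a functional assay on HT-29 cells (Homo sapiens) for inhibition, read by sulforhodamine B assay, with a stated time of 48 h (on this read-out higher numbers stand for weaker inhibition of growth and lower numbers for stronger inhibition of growth), compound 1 gives only a limit of the assay, > 100000 nM. Compound 2 gives 26900 nM. Within the data shown here, the single measured step in this assay is an at least 3.7-fold lower number from compound 1 to compound 2 (0.57 log units; beyond the scatter); its size is known only on one side because compound 1 sits at the limit of > 100000 nM in this assay, at which 1 of the 2 values shown sits.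

Compound 3, `CC1=CC[C@H](C(C)(C)NC(=S)N/N=C/c2cccs2)CC1`, is not yet measured. It differs from compound 1 thus: a group of 7 heavy atoms (5 carbon, 1 nitrogen, 1 sulfur; one five-membered aromatic ring with 1 hetero atom) in place of one nitrogen atom, on an amide-type nitrogen. Among the measured compounds shown here, the change is of the same kind as the one from compound 1 to compound 2, with the ring heteroatom being sulfur rather than oxygen. For the measured compounds named here, only the step from compound 1 to compound 2 bears on this; it was at least modest and beyond the scatter, towards stronger growth inhibition. A step of similar size and in the same direction is therefore expected in this assay, an at least 4.0-fold lower number from compound 1 to compound 3 (0.60 log units; beyond the scatter). On that basis the estimate for compound 3 in this assay is 25000 nM, with a range from 8000 nM to 80000 nM. A single measured step with a one-sided bound keeps this range wide.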

Compound 3, concentration for total growth inhibition: 57800 nM
The estimate for compound 3 lay 2.3-fold (0.36 log units) below the measured number; the measured number falls inside the stated range.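

In this assay, the change of furan-2-yl to thiophen-2-yl on the carbon with a double bond to nitrogen is not silent: a 2.1-fold higher number from compound 2 to compound 3 (0.33 log units; beyond the scatter), so the identity of the ring at this position affects the read-out, and the furan-2-yl member of the pair gives the stronger growth inhibition. Replacing amino on the amide-type nitrogen with the thiophen-2-yl group gives an at least 1.7-fold lower number from compound 1 to compound 3 (0.23 log units; that floor lies within the scatter), so the thiophen-2-yl group does not by this bound alone establish a gain, whereas the furan-2-yl group does. The true size of either step from the amino compound stays unknown, because only a limit and not a number is available there: the limit of > 100000 nM in this assay, at which 1 of the 3 values shown sits.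

Two rings that differ only in their hetero atom give no trend, and these compounds cannot tell what in the exchange of oxygen for sulfur produces the difference. As far as these compounds go, whether the order seen here holds for a phenyl or pyridin-2-yl ring on the same carbon, or when a carbonyl stands in place of the thiocarbonyl, remains open.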